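A few compounds are considered here, and "the series" means these few. Any claim that something is new, unique, unknown or untested is made for them only; others in the source may bear on it.

In a functional assay on 786-0 cells (Homo sapiens) for inhibition, read by sulforhodamine B assay, with a stated time of 48 h (on this read-out higher numbers stand for weaker inhibition of growth and lower numbers for stronger inhibition of growth), compound 3 (`O=C(Nc1cccc(-n2cc(-c3ccncc3)c(-c3ccc(Cl)c(O)c3)n2)c1)Nc1ccc(Cl)c(Cl)c1`) gives 7220 nM. That number cannot be told apart from the 4690 nM of compound 1 (`O=C(Nc1cccc(-n2cc(-c3ccncc3)c(-c3ccc(Cl)c(O)c3)n2)c1)Nc1cccc(C(F)(F)F)c1`), but it stands clearly on the weaker side of compound 2 (`COc1cc(-c2nn(-c3cccc(NC(=O)Nc4ccc(Cl)c(Cl)c4)c3)cc2-c2ccncc2)ccc1Cl`), which gives 1310 nM. Compound 4 (`O=C(Nc1cccc(-n2cc(-c3ccncc3)c(-c3ccc(Cl)c(O)c3)n2)c1)Nc1ccc(Cl)c(C(F)(F)F)c1`) keeps the core of compound 3 and carries one change: trifluoromethyl in place of chloro on an aromatic carbon. Trifluoromethyl takes the place of chloro on an aromatic carbon, ortho to a chloro group, so 3,4-dichlorophenyl becomes 4-chloro-3-(trifluoromethyl)phenyl. Going by the values given here, the closest evidence is a 1.5-fold higher number from compound 1 to compound 3 (0.19 log units; within the scatter), the one measured step that alters this same aryl group, and it stays within the scatter. The larger 5.5-fold higher number from compound 2 to compound 3 (0.74 log units; beyond the scatter) concerns hydrogen in place of methyl on an oxygen, a different part of the molecule, so it says little here. No step beyond the scatter is therefore expected in this assay, and the estimate is a 1.3-fold lower number from compound 3 to compound 4 (0.12 log units; within the scatter), with no firm direction. For compound 4 the expected value is 5500 nM, with an estimated range of 2500 nM to 12000 nM.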

Compound 4, concentration for 50% growth inhibition: 1280 nM
Compound 4: the middle estimate sits 4.3-fold (0.63 log units) above what was measured; the whole stated range lies above it.
By their numbers in this assay, from the lowest: compounds 4 and 2 (each within the scatter of the next); then compounds 1 and 3 (each within the scatter of the next).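

In this assay, trifluoromethyl in place of chloro gives a 5.6-fold lower number from compound 3 to compound 4 (0.75 log units; beyond the scatter), so this aryl group does respond to a change, which the earlier step within the scatter had not shown. Chloro in place of hydrogen on the same ring gives a 3.7-fold lower number from compound 1 to compound 4 (0.56 log units; beyond the scatter), so the stronger inhibition of growth appears only with trifluoromethyl and chloro together in 4-chloro-3-(trifluoromethyl)phenyl, while compound 1 and compound 3, each with only one of these features, stay within the scatter of each other. No measurement shown here explains this result.

Going by these compounds, whether a nitrile or a bromo group in place of the trifluoromethyl would keep the lower number remains open. So does whether a methyl on the phenolic oxygen of compound 4 would lower the number further.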